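The source may hold more compounds than are shown below. What is called first, only, known or untested is meant among the compounds shown, and "the series" means these compounds.

Two compounds of the series have numbers in a functional assay on A549 cells (Homo sapiens) for cytotoxicity, read by colorimetric assay and MTT assay, with a stated time of 3 days, tested at 1 uM; on this read-out higher numbers stand for a weaker effect at the one concentration tested and lower numbers for a stronger effect. Compound 1 `O=C1COc2ccc(-c3[nH]c(-c4c[nH]c5ncccc45)nc3-c3ccccc3)cc2N1` gives 100% in this assay, the highest of the two numbers; compound 2 `O=C1COc2ccc(-c3nn(-c4ccc(F)cc4)cc3-c3ccccc3)cc2N1` gives 78.2%, a number lower than that of compound 1 by more than the usual scatter. Among the compounds with values here, no pair that differs in one place has been measured, so no step is in hand. Compound 3 `O=C1COc2ccc(-c3[nH]c(-c4ccc(Cl)cc4Cl)nc3-c3ccccc3)cc2N1` is not yet measured in this assay. It differs from compound 1 by a group of 8 heavy atoms (6 carbon, 2 chlorine; one six-membered aromatic ring of carbon only) in place of a group of 9 heavy atoms (7 carbon, 2 nitrogen; one five-membered aromatic ring with 1 hetero atom, one six-membered aromatic ring with 1 hetero atom), on an aromatic carbon, the 2,4-dichlorophenyl entering on the aromatic carbon between two ring nitrogen atoms of the shared core. Within the data shown here, with only compound 1 as reference and no measured step, the expected step is a number 12 percentage points lower from compound 1 to compound 3 (beyond the scatter), modest and toward a stronger effect, at about the edge of the scatter. In this assay compound 3 is estimated at 88%, with a range from 65% to 105%.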

Compound 3, a percentage reported as activity, at one concentration (the size of the read-out at that concentration, not a potency): 97.4%
The estimate for compound 3 lay 9.4 percentage points below the measured number; the measured number falls inside the stated range.
By their numbers in this assay, from the lowest: compound 2; then compounds 3 and 1 (each within the scatter of the next).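

In this assay, putting 2,4-dichlorophenyl on the aromatic carbon between two ring nitrogen atoms, in place of the group of compound 1 with its five-membered and six-membered aromatic rings, gives a number 2.6 percentage points lower from compound 1 to compound 3 (within the scatter). This position therefore accepts a carbon-only aromatic ring bearing two chlorine atoms, with no hydrogen-bond donor or acceptor, and the read-out of this pair stays within the scatter, although the entering and leaving groups differ in ring type and atom content. No measurement on hand explains this outcome.

The pair leaves open whether any group at this position can give a clearly stronger effect in this assay, for example an unsubstituted phenyl, a pyridine ring, a small alkyl chain, an amine or a carboxylic acid. It also leaves open which of the two chlorine atoms, if either, matters, and how the pair compares across concentrations, since one concentration gives no potency.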